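A few compounds are considered here, and "the series" means these few. Any claim that something is new, unique, unknown or untested is made for them only; others in the source may bear on it.

Two compounds of this series have a measurement in a functional assay on MCF7 cells (Homo sapiens) for antiproliferative activity, read by CCK-8 assay, with a stated time of 72 h; on this read-out lower numbers stand for stronger inhibition of growth and higher numbers for weaker inhibition of growth. Compound 1, `CCC1C(=O)N(C)c2cnc(-n3ccc4cc(C(=O)NC(C)C)ccc43)nc2N1c1ccn(C)n1`, gives 8420 nM in this assay. Compound 2, `CC[C@@H]1C(=O)N(C)c2cnc(Nc3ccc(S(=O)(=O)NC)cc3)nc2N1C1CCCC1`, gives 151 nM in this assay, the lower of the two numbers and a gap from compound 1 that lies beyond the scatter of repeated measurements. Compound 3, `CC[C@@H]1C(=O)N(C)c2cnc(Nc3ccc(S(=O)(=O)NC4CCCC4)cc3)nc2N1C1CCCC1`, has not yet been measured. Its structure differs from compound 2 in one place only: cyclopentyl in place of methyl on a sulfonamide nitrogen. Going by the values given here, no pair of measured compounds shows what such a change does in this assay, so there is no directly comparable step to draw on. In the absence of such a reference, the author expects the step of a 1.3-fold higher number from compound 2 to compound 3 (0.12 log units; within the scatter) to be small, with no clear direction beyond the scatter. Compound 3 is therefore expected to give about 200 nM in this assay, within a range from 60 nM to 700 nM.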

Compound 3, concentration for 50% growth inhibition: 688 nM
Compound 3: the middle estimate sits 3.4-fold (0.54 log units) below what was measured, within the range that was stated.
By their numbers in this assay, from the lowest: compound 2; then compound 3; then compound 1.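

Going by these compounds alone, compound 3 gives the first reading of a change on a sulfonamide nitrogen: in this assay, cyclopentyl in place of methyl produces a 4.6-fold higher number from compound 2 to compound 3 (0.66 log units; beyond the scatter), a modest step but one that lies beyond the scatter. This position therefore responds to the group it carries, and of the two groups shown here, methyl goes with the stronger inhibition of growth. Nothing measured here offers a reason for this step.

Two groups cannot show whether the number rises steadily as the group on this nitrogen grows or whether it depends on the cyclopentyl ring itself. As far as these compounds go, how a bare hydrogen, an open chain such as isopropyl, or a piperidine ring carrying a basic amine would read at this nitrogen in this assay remains open.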